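The compounds below may be only part of what the source reports. "The series", "measured", "known", "first", "only" and "open" are said of these compounds alone.

Measured in a functional assay on the whole organism (arterial blood) with Rattus norvegicus as the target; on this read-out lower numbers stand for an effect already at smaller amounts and higher numbers for an effect only at larger amounts of compound:
Compound 1 `Cc1nc2cnccc2n1CC1CCN(C(=O)CC(C)(C)c2ccccc2)CC1`: 0.012 mg/kg
Compound 2 `Cc1nc2cnccc2n1CC1CCN(C(=O)CC(O)(c2ccccc2)c2ccccc2)CC1`: 0.013 mg/kg
Compound 3 `Cc1nc2cnccc2n1CC1CCN(C(=O)CC(C)(O)c2ccccc2)CC1`: 0.043 mg/kg

Compound 3, at 0.043 mg/kg, has the highest number of the three in this assay. Compound 4 `Cc1nc2cnccc2n1CC1CCN(C(=O)CC(O)(c2ccccc2)C(F)(F)F)CC1` carries trifluoromethyl in place of methyl on a saturated chain carbon bound to an aromatic carbon, an oxygen on a saturated carbon and a saturated chain carbon. Two modest steps bear on this. The closer one changes the same carbon, a 3.3-fold higher number from compound 2 to compound 3 (0.52 log units; beyond the scatter), and the other is a 3.6-fold higher number from compound 1 to compound 3 (0.55 log units; beyond the scatter). Among the compounds with values here, no measured compound carries trifluoromethyl, so the reading is uncertain. A modest fall in the number is expected, partly back toward compound 2 with its 0.013 mg/kg. The expected change is a 2.0-fold lower number from compound 3 to compound 4 (0.29 log units; within the scatter). For compound 4 the estimated value is 0.022 mg/kg, with an expected range of 0.007 mg/kg to 0.07 mg/kg.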

Compound 4, dose for 50% inhibition: 0.013 mg/kg
For compound 4 the middle estimate is 1.7-fold (0.23 log units) above the measured one; the measured number falls inside the stated range.
By their numbers in this assay, from the lowest: compounds 1, 2 and 4 (each within the scatter of the next); then compound 3.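

Read in this assay the carbon bearing the hydroxy group takes trifluoromethyl in place of methyl with a modest gain (a 3.3-fold lower number from compound 3 to compound 4 (0.52 log units; beyond the scatter)). Trifluoromethyl also stands level with phenyl on that carbon (no change at the digits printed from compound 2 to compound 4 (within the scatter)), so the higher number of compound 3 does not follow from the loss of phenyl alone. The compounds come with no measurement that would explain this.

As far as these compounds go, whether ethyl, cyclopropyl or an amine on that carbon would behave like trifluoromethyl stays open. So does the outcome of replacing the hydroxy group of compound 4 with methoxy.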